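The source may hold more compounds than are shown below. What is called first, only, known or untested is meant among the compounds shown, and "the series" means these compounds.

Working notes on the series.

Compound 1 `COc1ccc(S(=O)(=O)/C=C/c2ccccn2)cc1` is the parent of the set. In an assay on U2OS cells for activation of nuclear factor erythroid 2-related factor 2 (Homo sapiens), read by chemiluminescence, with a stated time of 6 h (on this read-out higher numbers stand for an effect only at larger amounts of compound and lower numbers for an effect already at smaller amounts), compound 1 sits at the limit of the assay, > 10000 nM, so only a bound and no number is known for it. The two measured steps both add a halogen to the ring attached to the double-bonded chain. Compound 2 `COc1ccc(S(=O)(=O)/C=C/c2cccc(Cl)n2)cc1` gives 3270 nM, and the step of an at least 3.0-fold lower number from compound 1 to compound 2 (0.48 log units; beyond the scatter). Compound 3 `COc1ccc(S(=O)(=O)/C=C/c2ncccc2F)cc1` gives 1080 nM, and the step of an at least 9.2-fold lower number from compound 1 to compound 3 (0.96 log units; beyond the scatter). Both steps are counted only against the bound of compound 1, since (the limit of > 10000 nM in this assay, at which 1 of the 3 values shown sits).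

Compound 4 `COc1ccc(S(=O)(=O)/C=C/c2cncnc2)cc1` has not been measured. The change from compound 1 is pyrimidin-5-yl in place of pyridin-2-yl on a double-bonded chain carbon bound to a double-bonded chain carbon. Within the data shown here, this replaces the ring itself rather than adding a halogen to it, so neither measured step bears on it directly; the halogen steps show only that the parent ring can be moved off its bound by substitution, not what a swap of the ring does. With no step of this kind in hand, the expectation for compound 4 is that it stays near the bound of compound 1, giving an estimated step that the limit leaves unreadable from compound 1 to compound 4. Compound 4 is therefore estimated at 15000 nM, within a range of 4000 nM to 50000 nM, with a real chance that this assay again reports only a limit.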

Compound 4, half-maximal effective concentration: > 10000 nM
Compound 4: only a limit was reported; the forecaster's own chance of this, stated with the estimate: 60%; the middle value does not contradict the limit.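

In this assay compound 4 gives > 10000 nM, which is a limit of the assay. No step can be read between compound 1 and compound 4, because both stand at a limit: the limit of > 10000 nM in this assay, at which 2 of the 4 values shown sit. The compounds shown leave open whether pyrimidin-5-yl in place of pyridin-2-yl changes the read-out at all.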